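Cytotoxicity across three amides and a hydroxy-to-methyl exchange

A few compounds are considered here, and "the series" means these few. Any claim that something is new, unique, unknown or untested is made for them only; others in the source may bear on it.

Compound 1 `COc1ccc(-c2cnc(NC(=O)c3ccccc3O)n2C)cc1`: > 100000 nM
Compound 2 `Cn1cc(-c2ccccc2)nc1NC(=O)c1ccc(F)cc1`: > 50000 nM
Compound 3 `Cc1ccc(-c2cnc(NC(=O)c3ccc(F)cc3)n2C)cc1`: 60000 nM

In a toxicity assay on THP-1 cells (Homo sapiens) for inhibition (on this read-out higher numbers stand for lower toxicity in this test and lower numbers for higher toxicity in this test), compound 1 gives > 100000 nM, which is a limit of the assay and not a number. Compound 1 therefore stands at the limit of > 100000 nM in this assay, at which 1 of the 3 values shown sits. Compound 2 likewise gives only a limit in this assay, > 50000 nM, and sits at the limit of > 50000 nM in this assay, at which 1 of the 3 values shown sits. Going by the values given here, compound 3 is the one compound with a numerical reading in this assay, 60000 nM. Among the compounds with values here, all three values speak for low toxicity in this test, and no pair of compounds differs in only one place, so no measured step is available.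

Compound 4 `COc1ccc(-c2cnc(NC(=O)c3ccccc3C)n2C)cc1` is not yet measured. It differs from compound 1 by methyl in place of hydroxy on an aromatic carbon. Given how compound 1 sits at the limit of > 100000 nM in this assay, at which 1 of the 3 values shown sits, compound 4 is expected to remain at low toxicity in this assay. The change is expected to amount to a number no higher from compound 1 to compound 4 (the limit leaves the size open), which would be no step beyond the usual scatter. Compound 4 is estimated at 100000 nM in this assay, with a range from 40000 nM to 250000 nM.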

Compound 4, half-maximal cytotoxic concentration: > 100000 nM
Compound 4 was reported as a limit (the forecaster's own chance of this, stated with the estimate: 70%); the middle value sits exactly at the limit.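

Compound 1 and compound 4 both stand at a limit in this assay, so no step between them can be read: the limit of > 100000 nM in this assay, at which 2 of the 4 values shown sit.

The compounds shown leave open whether methyl in place of hydroxy changes the reading at all, since neither compound has a numerical value.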